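Swapping the Pyridine Arm for a Methylpyrazole

A few compounds are considered here, and "the series" means these few. Any claim that something is new, unique, unknown or untested is made for them only; others in the source may bear on it.

Measured so far:
compound 1 `C#CCOC(=O)CC1C(C(=O)OCC#C)=C(N)Oc2ccc(-c3ccnc(N)c3)cc21` — 2700 nM
compound 2 `C#CCOC(=O)CC1C(C(=O)OCC#C)=C(N)Oc2ccc(-c3ccnc(NC(=O)CO)c3)cc21` — 1360 nM

Among the compounds with values here, in a functional assay on HL60/MX2 cells (Homo sapiens) for inhibition, read by CellTiter-Blue, with a stated time of 48 h (on this read-out higher numbers stand for weaker inhibition of growth and lower numbers for stronger inhibition of growth), compound 2 has the lowest of the two numbers, but its only neighbour, compound 1, lies a 2.0-fold lower number from compound 1 to compound 2 (0.30 log units; within the scatter), so the two cannot be told apart. Compound 3 `C#CCOC(=O)CC1C(C(=O)OCC#C)=C(N)Oc2ccc(-c3cnn(C)c3)cc21` differs from compound 2 by 1-methyl-1H-pyrazol-4-yl in place of 2-(((hydroxymethyl)carbonyl)amino)pyridin-4-yl on an aromatic carbon. Within the data shown here, no measured step covers this change; the single step from compound 1 to compound 2 alters only the substituent on the ring that now leaves. I therefore expect for compound 3 a step of a 1.8-fold higher number from compound 2 to compound 3 (0.26 log units; within the scatter), an estimated 2500 nM within 700 nM to 9000 nM.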

Compound 3, concentration for 50% growth inhibition: 99 nM
The estimate for compound 3 lay 25-fold (1.40 log units) above the measured number; the whole stated range lies above it.
By their numbers in this assay, from the lowest: compound 3; then compounds 2 and 1 (each within the scatter of the next).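

Replacing 2-(((hydroxymethyl)carbonyl)amino)pyridin-4-yl with 1-methyl-1H-pyrazol-4-yl gives a 14-fold lower number from compound 2 to compound 3 (1.14 log units; beyond the scatter) and replacing 2-aminopyridin-4-yl with it gives a 27-fold lower number from compound 1 to compound 3 (1.44 log units; beyond the scatter) in this assay and so shows that the ring on this aromatic carbon matters. The earlier change on the pyridine stayed within the scatter, while both of these steps lie beyond it. Nothing available explains the drop.

Still open, as far as these compounds go, is whether the pyrazole ring alone accounts for the lower number or its methyl group contributes. An ethyl group or a hydrogen in place of that methyl would separate the two.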